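A few compounds are considered here, and "the series" means these few. Any claim that something is new, unique, unknown or untested is made for them only; others in the source may bear on it.

Working notes on the series, read in a functional assay on U-251 cells (Homo sapiens); a higher number here means a weaker inhibitor of growth, a lower number a stronger inhibitor of growth. Compound 1 `O=S(=O)(/C=C/c1ccc(Br)cc1)Cc1ccc(Nc2ncnc3ccc(Br)cc23)cc1` gives 11000 nM. Compound 3 `O=S(=O)(/C=C/c1ccc(C(F)(F)F)cc1F)Cc1ccc(Nc2ncnc3ccc(Br)cc23)cc1` gives 30000 nM, the higher of the two actual numbers in the set, and it stands nearest to compound 1, with a 2.7-fold higher number from compound 1 to compound 3 (0.44 log units; beyond the scatter). Compound 2 `O=S(=O)(/C=C/c1ccc(O)cc1)Cc1ccc(Nc2ncnc3ccc(Br)cc23)cc1` is reported only as a limit, > 100000 nM.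

Compound 4 `O=S(=O)(/C=C/c1ccc(C(F)(F)F)cc1F)Cc1ccc(Nc2ncnc3cc(Cl)ccc23)cc1` keeps the 2-fluoro-4-(trifluoromethyl)phenyl group of compound 3 and differs in one place: a group of 11 heavy atoms (8 carbon, 2 nitrogen, 1 chlorine; one six-membered aromatic ring of carbon only, one six-membered aromatic ring with 2 hetero atoms) in place of a group of 11 heavy atoms (8 carbon, 2 nitrogen, 1 bromine; one six-membered aromatic ring of carbon only, one six-membered aromatic ring with 2 hetero atoms), on a nitrogen on an aromatic ring. The entering group is 7-chloroquinazolin-4-yl. For the measured compounds named here, no measured step touches this place. Going by the values given here, the steps of an at least 9.0-fold higher number from compound 1 to compound 2 (0.95 log units; beyond the scatter), a 2.7-fold higher number from compound 1 to compound 3 (0.44 log units; beyond the scatter) and an at least 3.3-fold lower number from compound 2 to compound 3 (0.52 log units; beyond the scatter) all change the aryl group on the double-bonded chain carbon, so they show only that single changes elsewhere can reach beyond the scatter. They give no direction for this change, so no step beyond the scatter is expected in this assay, though the uncertainty is wide. The estimated step is no change at the digits printed from compound 3 to compound 4 (within the scatter). For compound 4 the estimated value is 30000 nM, with an expected range of 10000 nM to 90000 nM.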

Compound 4, concentration for 50% growth inhibition: > 100000 nM
Compound 4: a limit, no number; the forecaster's own chance of this, stated with the estimate: 20%; middle value at least 3.3-fold (0.52 log units) away from the limit.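

For the compounds shown here, this is the first step at the group on the nitrogen on an aromatic ring: in this assay, 7-chloroquinazolin-4-yl in place of the bromine-bearing group gives an at least 3.3-fold higher number from compound 3 to compound 4 (0.52 log units; beyond the scatter). This place therefore responds to a change that leaves the heavy-atom count of the group as it was, and it can no longer be treated as silent. The value of compound 4 is a limit and not a number, so the step has a lower bound but no full size: the limit of > 100000 nM in this assay, at which 2 of the 4 values shown sit.

The compounds shown leave open whether 7-chloroquinazolin-4-yl gives a step of the same direction when paired with the 4-bromophenyl group of compound 1 rather than the 2-fluoro-4-(trifluoromethyl)phenyl group. They also leave open what an amine or a methoxy group in place of the chlorine would give at this place.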